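The source may report more compounds than this note shows. Statements on the series, on what has been measured and on what is new or still open speak of the compounds shown alone.

A family of esters on one shared core was tested in an ADME assay on HepG2 2.2.15 cells (Homo sapiens) for cytotoxicity; a lower number here means that less compound is tolerated, a higher number that more compound is tolerated. Here compound 1 `CCCC(=O)OCCc1c(-c2ccccc2Cl)c2cc(Cl)ccc2[nH]c1=O`, with propyl on the carbonyl carbon, gives 52000 nM as a measured number. Compound 2 `O=C(/C=C/c1ccc(C(F)(F)F)cc1)OCCc1c(-c2ccccc2Cl)c2cc(Cl)ccc2[nH]c1=O` gives only a limit, > 1400000 nM, and no exact number. Compound 3 `COc1ccc(/C=C/C(=O)OCCc2c(-c3ccccc3Cl)c3cc(Cl)ccc3[nH]c2=O)cc1OC` also gives only a limit, > 1200000 nM, which places it at the well-tolerated end of the numbers shown.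

Compound 4 `C/C=C/C(=O)OCCc1c(-c2ccccc2Cl)c2cc(Cl)ccc2[nH]c1=O` is not yet measured. It has methyl in place of 3,4-dimethoxyphenyl on a double-bonded chain carbon bound to a double-bonded chain carbon, as counted here: methyl in place of 3,4-dimethoxyphenyl on a double-bonded chain carbon bound to a double-bonded chain carbon. This leaves a prop-1-en-1-yl chain, which resembles the propyl of compound 1. Among the compounds with values here, two measured steps bear on the change: an at least 23-fold higher number from compound 1 to compound 3 (1.36 log units; beyond the scatter) and an at least 26-fold higher number from compound 1 to compound 2 (1.43 log units; beyond the scatter), both large, and both going with a phenyl-bearing ethenyl group. Losing that ring is expected to undo most of the rise. A large step is therefore expected in this assay: an at least 20-fold lower number from compound 3 to compound 4 (1.30 log units; beyond the scatter), towards a lower number. The estimate for compound 4 is 60000 nM, with an expected range from 20000 nM to 250000 nM.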

Compound 4, half-maximal cytotoxic concentration: 30000 nM
Beside the measured number, compound 4's estimate is 2.0-fold (0.30 log units) above it; the measured number falls inside the stated range.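

In this assay, keeping the double bond but losing the aromatic ring brings the number back down: methyl in place of 3,4-dimethoxyphenyl gives an at least 40-fold lower number from compound 3 to compound 4 (1.60 log units; beyond the scatter), and methyl in place of 4-(trifluoromethyl)phenyl gives an at least 46-fold lower number from compound 2 to compound 4 (1.66 log units; beyond the scatter). The double bond by itself leaves no difference that can be read, as prop-1-en-1-yl in place of propyl gives a 1.7-fold lower number from compound 1 to compound 4 (0.24 log units; within the scatter). Among these four compounds, then, the high numbers go with an aromatic ring on the ethenyl group and not with the double bond alone.

From the compounds shown here alone, how far the ring raises the number stays open, with compound 3 known only as a limit: the limit of > 1200000 nM in this assay, at which 1 of the 4 values shown sits. Whether a longer chain such as pentyl, or an amine in place of the ring, would also give high numbers is not settled by these compounds.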